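Working notes: from compound 3 to compound 4

This account rests on a few compounds, and the source may have more. Where it says the series, first, only, none or still open, it means among the compounds named here.

Measured so far in a functional assay on MCF7 cells (Homo sapiens) for inhibition, with a stated time of 72 h; on this read-out higher numbers stand for weaker inhibition and lower numbers for stronger inhibition:
- compound 1 `NC1CCC(Nc2nc(NCc3ccc(-c4ccccc4)cc3)c3ncn(C4CCCC4)c3n2)CC1`: 583 nM
- compound 2 `NC1CCC(Nc2nc(NCc3ccc(-c4ccco4)cc3)c3ncn(C4CCCC4)c3n2)CC1`: 85 nM
- compound 3 `NC1CCC(Nc2nc(NCc3ccc(-n4cccn4)cc3)c3ncn(C4CCCC4)c3n2)CC1`: 139 nM

Compound 3 at 139 nM stands level with compound 2, the gap being a 1.6-fold higher number from compound 2 to compound 3 (0.21 log units; within the scatter) and both lie clearly under compound 1.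

The next structure is compound 4 `NC1CCC(Nc2nc(NCc3ccc(-c4ccco4)nc3)c3ncn(C4CCCC4)c3n2)CC1`, where 6-(furan-2-yl)pyridin-3-yl comes in place of 4-(1H-pyrazol-1-yl)phenyl on a saturated chain carbon bound to a nitrogen on an aromatic ring. The counted difference is 6-(furan-2-yl)pyridin-3-yl in place of 4-(1H-pyrazol-1-yl)phenyl on a saturated chain carbon bound to a nitrogen on an aromatic ring and it has two parts.

The exchange of the five-membered ring has a measured counterpart in the step between compound 2 and compound 3, which stayed inside the scatter. The two larger steps, a 6.9-fold lower number from compound 1 to compound 2 (0.84 log units; beyond the scatter) and a 4.2-fold lower number from compound 1 to compound 3 (0.62 log units; beyond the scatter), show that either five-membered ring gave a similar drop from phenyl. For the measured compounds named here, no measured step covers the nitrogen entering the six-membered ring, so that part remains open and widens the range.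

In this assay the expected outcome is a 1.1-fold lower number from compound 3 to compound 4 (0.03 log units; within the scatter) and no step beyond the scatter is expected in either direction. For compound 4 the estimated value is 130 nM with an expected range from 45 nM to 400 nM on this evidence.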

Compound 4, half-maximal inhibitory concentration: 33 nM
Estimate against measurement, compound 4: 3.9-fold (0.60 log units) above; the measured number lies below the stated range.
By their numbers in this assay, from the lowest: compound 4; then compounds 2 and 3 (each within the scatter of the next); then compound 1.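

In this assay, for the compounds shown here, the step to 6-(furan-2-yl)pyridin-3-yl with the furan-2-yl kept, a 2.6-fold lower number from compound 2 to compound 4 (0.41 log units; beyond the scatter), is the first reading of a nitrogen in the six-membered ring on this saturated chain carbon, and it lies beyond the scatter, whereas the earlier compounds varied only the outer ring on a carbon-only six-membered ring. The other two steps, a 4.2-fold lower number from compound 3 to compound 4 (0.62 log units; beyond the scatter) and an 18-fold lower number from compound 1 to compound 4 (1.25 log units; beyond the scatter), also exchange the outer ring, so neither isolates the nitrogen, yet together they place the new group ahead of every earlier compound, and the six-membered ring, not only the ring attached to it, now counts as a variable that moves the number at this position. No supporting measurement is available to explain why this exchange changes the cell result.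

Open is whether the ring nitrogen gives a similar step with 1H-pyrazol-1-yl or phenyl as the outer ring, as compound 4 alone among those shown holds that nitrogen. Also open, as far as these compounds go, is how a methoxy group or a morpholine ring would read in place of the furan-2-yl on the same six-membered ring.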